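Cyano in Place of Fluoro on a Cinnamoyl Ring

The compounds below may be only part of what the source reports. "The series", "measured", "known", "first", "only" and "open" are said of these compounds alone.

Compound 1 `CC1=C(/C=C/C(=O)/C=C/c2ccccc2)C(C)(C)CCC1` is a dienone that joins a substituted cyclohexenyl ring to an unsubstituted benzene ring. In a functional assay on HeLa cells (Homo sapiens) for cytotoxicity, read by sulforhodamine B assay, with a stated time of 48 h (on this read-out lower numbers stand for stronger inhibition and higher numbers for weaker inhibition), compound 1 gives 70200 nM, the highest of the two numbers recorded here. Its nearest neighbour is compound 2 `CC1=C(/C=C/C(=O)/C=C/c2ccc(F)cc2)C(C)(C)CCC1`, which carries a fluorine on the benzene ring and in this assay gives 32200 nM. That single change, fluoro in place of hydrogen on an aromatic carbon, produced a 2.2-fold lower number from compound 1 to compound 2 (0.34 log units; beyond the scatter).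

Compound 3 `CC1=C(/C=C/C(=O)/C=C/c2ccc(C#N)cc2)C(C)(C)CCC1` has not been measured. It differs from compound 1 by cyano in place of hydrogen on an aromatic carbon. Among the measured compounds shown here, only one measured step bears on this change, the fluorine step from compound 1 to compound 2, and it was modest. A cyano group is a larger, different substituent at the same place, so the measured step gives only a rough guide. The expectation is that compound 3 will show a modest drop, as a step of a 1.8-fold lower number from compound 1 to compound 3 (0.24 log units; within the scatter). Compound 3 is therefore estimated at 40000 nM, with a plausible range from 15000 nM to 100000 nM.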

Compound 3, half-maximal inhibitory concentration: 22200 nM
Beside the measured number, compound 3's estimate is 1.8-fold (0.26 log units) above it; the measured number falls inside the stated range.
By their numbers in this assay, from the lowest: compounds 3 and 2 (each within the scatter of the next); then compound 1.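

In this assay, this position now accepts a second substituent with a result in the same direction (a 3.2-fold lower number from compound 1 to compound 3 (0.50 log units; beyond the scatter)), so the drop from compound 1 is no longer tied to fluoro alone. Exchanging the two substituents for each other gives a change that cannot be told apart from ordinary assay noise (a 1.5-fold lower number from compound 2 to compound 3 (0.16 log units; within the scatter)), so compound 2 and compound 3 cannot be ranked against each other, and only compound 1, with hydrogen at this place, stands apart as the weakest of the three. Nothing measured here explains why either group lowers the number, so the result stays a plain observation about these three compounds.

The compounds shown hold only two substituents at this one place on the shared core, so it remains open whether an amine, a carboxylic acid or a methoxy group there would lower the number as well or raise it. On these data alone, it also remains open whether cyano or fluoro would give a similar result at another carbon of the aromatic ring.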